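The source may hold more compounds than are shown below. What is called first, only, known or untested is meant among the compounds shown, and "the series" means these compounds.

In a functional assay for binding affinity, with Homo sapiens as the target, read by fluorescence and flow cytometry (a lower number here means tighter binding, a higher number weaker binding), compound 3 (`O=C(NC[C@H](NS(=O)(=O)c1cccs1)C(=O)O)c1cc2sc(CCC3CCNCC3)cc2s1`) gives 0.092 nM, which is within the scatter of compound 1 (`O=C(NC[C@H](NS(=O)(=O)c1cccs1)C(=O)O)c1cc2cc(CCC3CCNCC3)sc2s1`) at 0.15 nM, while compound 2 (`O=C(NC[C@H](NS(=O)(=O)c1ccc(Cl)cc1)C(=O)O)c1cc2cc(CCC3CCNCC3)sc2s1`) gives 0.026 nM. The number for compound 2 is lower than that for compound 3, and this gap lies beyond the scatter. Compound 4 (`CCCCS(=O)(=O)N[C@@H](CNC(=O)c1cc2sc(CCC3CCNCC3)cc2s1)C(=O)O`) carries butyl in place of thiophen-2-yl on a sulfonyl sulfur. Within the data shown here, one measured step bears on this place, a 5.8-fold lower number from compound 1 to compound 2 (0.76 log units; beyond the scatter), with 4-chlorophenyl in place of thiophen-2-yl. Among the measured compounds shown here, it exchanged one ring for another, and no measured compound has a chain there, so the guidance is weak. A modest move towards weaker binding is expected, smaller than that step. The estimated step is a 2.2-fold higher number from compound 3 to compound 4 (0.34 log units; beyond the scatter). For compound 4 the expected value is 0.2 nM, with an estimated range of 0.06 nM to 0.7 nM.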

Compound 4, dissociation constant: 3 nM
The estimate for compound 4 lay 15-fold (1.18 log units) below the measured number; measured number above the stated range.
By their numbers in this assay, from the lowest: compound 2; then compounds 3 and 1 (each within the scatter of the next); then compound 4.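

In this assay, among these compounds, the only earlier step at this place exchanged one ring for another and gave a 5.8-fold lower number from compound 1 to compound 2 (0.76 log units; beyond the scatter). Putting an open chain on the sulfonyl sulfur instead gives a 33-fold higher number from compound 3 to compound 4 (1.51 log units; beyond the scatter), a large step towards weaker binding, so this position does not accept every group alike. No measurement shown here accounts for the size of this step. The compounds shown leave open whether the ring itself matters or only the particular chain, since they cannot separate the two. A cyclohexyl ring, a benzyl group or a longer chain on the same sulfur would bear on that question.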